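Swapping tert-butyl for 4-methoxyphenyl on a pyrazolone-type core

The source may report more compounds than this note shows. Statements on the series, on what has been measured and on what is new or still open speak of the compounds shown alone.

Three compounds have been run in an assay on isolated protein for inhibition of ribosomal protein S6 kinase alpha-1 (Homo sapiens), read by mobility shift assay, tested at 30 uM; a higher number here means more inhibition at the concentration tested (going by the name of the read-out), a lower number less inhibition. Compound 1 `COc1ccc(-c2cc3[nH]nc(N)c3c(=O)[nH]2)cc1` gives 7% in this assay, compound 2 `Cc1cc2c(c(NS(C)(=O)=O)nn2C)c(=O)[nH]1` gives -6%, and compound 3 `CC(C)(C)c1cc2nn(-c3ccccc3)c(N)c2c(=O)[nH]1` gives 5%. Compound 3 stands second highest of the three numbers: compound 1 lies within the scatter of it, while compound 2 lies beyond the scatter, lower. Compound 4 `COc1ccc(-c2cc3nn(-c4ccccc4)c(N)c3c(=O)[nH]2)cc1` has not yet been measured. It differs from compound 3 in one place: 4-methoxyphenyl in place of tert-butyl on an aromatic carbon. Compound 1 already carries the same 4-methoxyphenyl group on its core and gives 7%, so no step beyond the scatter is expected here. The step expected from compound 3 to compound 4 is a number 1 percentage points higher from compound 3 to compound 4 (within the scatter). For compound 4 the estimate is 6%, in a range of -6% to 18%.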

Compound 4, a percentage reported as inhibition, at one concentration (the size of the read-out at that concentration, not a potency): 4%
Estimate against measurement, compound 4: 2 percentage points above, and the stated range covers the measured number.
By their numbers in this assay, from the lowest: compounds 2, 4, 3 and 1 (each within the scatter of the next, the first and the last beyond it).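

In this assay, 4-methoxyphenyl in place of tert-butyl on the aromatic carbon next to the ring nitrogen gives a number 1 percentage points lower from compound 3 to compound 4 (within the scatter), so on this core a group with a six-membered aromatic ring and a branched carbon group sit at this place with no step beyond the scatter. Both numbers are small, so the step says little about how this position would behave in a compound showing clear inhibition. No available evidence explains the size of this step. Open, on these data alone, is whether an amine or a carboxylic acid at this aromatic carbon would move the number beyond the scatter.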